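The source may hold more compounds than are shown below. What is called first, only, known or untested is meant among the compounds shown, and "the series" means these compounds.

Working notes on a small thioether series examined for cytotoxicity.

Compound 2 `CC(C)c1c(CC2CCCCC2)nc(SCC(=O)c2ccccc2)[nH]c1=O` gives 0.025 nM in an ADME assay on C1866 cells (Homo sapiens) for cytotoxicity, read by MTT assay, with a stated time of 72 h; on this read-out lower numbers stand for an effect already at smaller amounts and higher numbers for an effect only at larger amounts of compound. Compound 1 `COc1ccc(C(=O)CSc2nc(CC3CCCCC3)c(C(C)C)c(=O)[nH]2)cc1` carries methoxy in place of hydrogen on an aromatic carbon relative to compound 2; in this assay compound 1 gives 0.162 nM, a step of a 6.5-fold higher number from compound 2 to compound 1 (0.81 log units; beyond the scatter). Compound 3 `CC(C)c1c(Cc2ccccc2)nc(SCC(=O)c2ccccc2)[nH]c1=O` differs from compound 2 in the core, (phenyl in place of cyclohexyl on a saturated chain carbon bound to an aromatic carbon); compound 3 gives 14 nM, the step being a 560-fold higher number from compound 2 to compound 3 (2.75 log units; beyond the scatter); compound 3 thus stands highest of the three measured compounds.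

Compound 4 `COc1ccc(C(=O)CSc2nc(Cc3ccccc3)c(C(C)C)c(=O)[nH]2)cc1` has not been measured. It differs from compound 3 by methoxy in place of hydrogen on an aromatic carbon, the same change that separates compound 1 from compound 2, and it occurs twice among the compounds shown. The two cores on which the change is made differ as stated for compound 3 against compound 2.

Going by the values given here, for compound 4 a step of about a 4.3-fold higher number from compound 3 to compound 4 (0.63 log units; beyond the scatter) from compound 3 is expected, resting on the single precedent of a 6.5-fold higher number from compound 2 to compound 1 (0.81 log units; beyond the scatter) and on the value of compound 3, 14 nM. Among the compounds with values here, with only one earlier instance on a different core, the range is kept wide. Compound 4 is accordingly estimated at 60 nM, between 15 nM and 300 nM.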

Compound 4, half-maximal effective concentration: 144 nM
For compound 4 the middle estimate is 2.4-fold (0.38 log units) below the measured one; the range from low to high includes it.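

In this assay methoxy in place of hydrogen on the phenyl ketone gives a 10-fold higher number from compound 3 to compound 4 (1.01 log units; beyond the scatter), and this step carries over from the cyclohexyl core to the phenyl core without a readable difference: the same change on two cores in this assay, a 6.5-fold higher number (0.81 log units; beyond the scatter) from compound 2 to compound 1 and a 10-fold higher number (1.01 log units; beyond the scatter) from compound 3 to compound 4, 1.6-fold (0.20 log units) apart, within the scatter of two such steps

Read the other way, phenyl in place of cyclohexyl in the methoxy pair gives an 890-fold higher number from compound 1 to compound 4 (2.95 log units; beyond the scatter), and this step also matches the one seen without methoxy: the same change on two cores in this assay, a 560-fold higher number (2.75 log units; beyond the scatter) from compound 2 to compound 3 and an 890-fold higher number (2.95 log units; beyond the scatter) from compound 1 to compound 4, 1.6-fold (0.20 log units) apart, within the scatter of two such steps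

Across these four compounds the two changes therefore behave as independent steps with no compound going against this, but that rests on a single pair of cores and does not show that the methoxy step would hold on any other core, nor does it say why either change raises the number.

The compounds shown leave open whether an amine, a carboxylic acid or a chlorine on the same aromatic carbon would move the number as methoxy does. They also leave open whether methoxy on another carbon of that ring, or a longer chain in place of methoxy, would keep a step of this size.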